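Swapping the Ethylphenyl for Methoxypyridinyl on the Amide Nitrogen

A few compounds are considered here, and "the series" means these few. Any claim that something is new, unique, unknown or untested is made for them only; others in the source may bear on it.

In an assay on CHO cells, read by calcium flux (a higher number here means a weaker inhibitor, a lower number a stronger inhibitor), compound 1 `CC(C)(C)c1ccc(NC(=O)c2csc(Cc3c(Cl)cccc3Cl)n2)cc1` gives 300 nM, while compound 2 `CCc1ccc(NC(=O)c2csc(Cc3c(Cl)cccc3Cl)n2)cc1` gives 1450 nM, the higher of the two numbers. For the measured compounds named here, the single measured step, a 4.8-fold higher number from compound 1 to compound 2 (0.68 log units; beyond the scatter), came from putting ethyl in place of tert-butyl on an aromatic carbon. Compound 3 `COc1ccc(NC(=O)c2csc(Cc3c(Cl)cccc3Cl)n2)cn1` differs from compound 2 by 6-methoxypyridin-3-yl in place of 4-ethylphenyl on an amide-type nitrogen. Going by the values given here, no measured step exchanges the whole aryl group, so the earlier step bears on this one only loosely, showing that the group on the amide nitrogen can move the number by a modest amount. A step of uncertain direction and modest size is therefore expected, a 1.0-fold higher number from compound 2 to compound 3 (0.01 log units; within the scatter). Compound 3 is estimated at 1500 nM, within 400 nM to 6000 nM.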

Compound 3, half-maximal inhibitory concentration: > 4000 nM
Compound 3 gave a limit, no number; the forecaster's own chance of this, stated with the estimate: 10%; middle value at least 2.6-fold (0.42 log units) away from the limit.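

In this assay compound 3 gives > 4000 nM, which is a limit and not a number. Exchanging the whole aryl group on the amide-type nitrogen still fixes a direction, with an at least 2.7-fold higher number from compound 2 to compound 3 (0.44 log units; beyond the scatter), whereas the earlier step changed only the alkyl group on a phenyl ring. The position therefore responds to a change in the ring itself, and 6-methoxypyridin-3-yl gives a weaker inhibitor than 4-ethylphenyl.

The compounds shown leave open how far the true value lies past the limit, and whether the ring nitrogen or the methoxy group accounts for the step. They also leave open how a ring bearing an amine or a carboxylic acid would read.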